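Moving a methyl on the aryl of compound 4

The compounds below may be only part of what the source reports. "The series", "measured", "known", "first", "only" and "open" are said of these compounds alone.

Compound 3 `Cc1ccc(C)c(N2C(=N)S/C(=C\c3ccc(OCc4ccccc4)cc3)C2=O)c1` gives 45.8% in an ADME assay on RAW264.7 cells (Mus musculus) for cytotoxicity, read by MTT assay, with a stated time of 48 h, tested at 50 uM (on this read-out higher numbers stand for more inhibition at the one concentration tested (going by the name of the read-out) and lower numbers for less inhibition), second highest of the three numbers. Compound 2 `N=C1S/C(=C\c2ccc(OCc3ccccc3)cc2)C(=O)N1c1cccc([N+](=O)[O-])c1` gives 52.9%, and a number 7.1 percentage points lower from compound 2 to compound 3 (within the scatter). Compound 1 `N=C1S/C(=C\c2ccc(OCc3ccccc3)cc2)C(=O)N1c1ccc(F)cc1` gives 10.5%, and a number 35.3 percentage points higher from compound 1 to compound 3 (beyond the scatter); similarly a number 42.4 percentage points higher from compound 1 to compound 2 (beyond the scatter). Compound 4 `Cc1cccc(C)c1N1C(=N)S/C(=C\c2ccc(OCc3ccccc3)cc2)C1=O` differs from compound 3 by 2,6-dimethylphenyl in place of 2,5-dimethylphenyl on an amide-type nitrogen in a ring. Every measured step swaps the aryl on that same ring nitrogen, so all three bear on this change; two were large and one lay within the scatter. Nothing measured moves a single methyl around the ring, so the expectation is a step of modest size: a number 3.8 percentage points lower from compound 3 to compound 4 (within the scatter). Compound 4 is therefore estimated at 42%, between 25% and 60%.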

Compound 4, a percentage reported as inhibition, at one concentration (the size of the read-out at that concentration, not a potency): 38.7%
For compound 4 the middle estimate is 3.3 percentage points above the measured one, and the stated range covers the measured number.
By their numbers in this assay, from the lowest: compound 1; then compounds 4, 3 and 2 (each within the scatter of the next, the first and the last beyond it).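

In this assay, shifting one methyl around the aryl gives a number 7.1 percentage points lower from compound 3 to compound 4 (within the scatter), so the 2,5-dimethylphenyl and 2,6-dimethylphenyl groups cannot be told apart here. Yet the 2,6-dimethylphenyl group does separate from 3-nitrophenyl, with a number 14.2 percentage points lower from compound 2 to compound 4 (beyond the scatter), a gap the 2,5-dimethylphenyl group did not open, and it also stands apart from 4-fluorophenyl, with a number 28.2 percentage points higher from compound 1 to compound 4 (beyond the scatter). Nothing measured here explains these steps. Still open, going by these compounds, is where an unsubstituted phenyl, or an aryl carrying an amine or a carboxylic acid, would fall on this scale.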